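The source may report more compounds than this note shows. Statements on the series, on what has been measured and on what is new or still open speak of the compounds shown alone.

Compounds measured in an ADME assay on the whole organism with Oryza sativa as the target, tested at 10 uM; a lower number here means a stronger effect, a higher number a weaker effect of the compound at the concentration tested:

compound 1 `CCCc1ccc(NC(=O)N[C@H](C)c2ccccc2)cc1` — 35%
compound 2 `CCCc1ccc(NC(=O)N[C@@H](C)c2ccccc2)cc1` — 73%
compound 3 `CC(=O)c1ccccc1NC(=O)N[C@H](C)c1ccccc1` — 89%

Compound 2 stands second highest of the three numbers in this assay. Its nearest neighbour is compound 3, which gives 89%, a number beyond the scatter above it; furthest from it is compound 1, which gives 35%, well below. Going by the values given here, the one step that can be followed within the set, a number 38 percentage points higher from compound 1 to compound 2 (beyond the scatter), rests only on (the fact that compounds 1 and 2 differ only in the configuration as drawn), since the two compounds carry the same atoms and bonds.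

Compound 4 `C[C@H](NC(=O)Nc1ccc(I)cc1)c1ccccc1` is not yet measured. It departs from compound 2 by iodo in place of propyl on an aromatic carbon. Among the compounds with values here, no measured step bears on this change: the single step in the set concerns configuration alone, and compound 3 differs from compound 2 in more than one place, so only its value can be set beside that of compound 2. With nothing to point either way, compound 4 is expected to stay close to compound 2, with a number 3 percentage points lower from compound 2 to compound 4 (within the scatter) expected to remain within the scatter. Compound 4 is therefore estimated at 70%, in a range from 40% to 95%.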

Compound 4, a percentage reported as activity, at one concentration (the size of the read-out at that concentration, not a potency): 95%
For compound 4 the middle estimate is 25 percentage points below the measured one; measured number inside the range.
By their numbers in this assay, from the lowest: compound 1; then compound 2; then compounds 3 and 4 (each within the scatter of the next).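

In this assay, the aromatic carbon para to a large group turns out to be sensitive to its substituent, with a number 22 percentage points higher from compound 2 to compound 4 (beyond the scatter) on iodo in place of propyl. Going by these compounds alone, the earlier step concerned configuration alone, so this is the first sign that a change on the aromatic ring, and not only at the stereocentre, can weaken the effect beyond the scatter. Nothing in the information available explains why this exchange has that effect.

The compounds shown leave open whether a single atom or the loss of the propyl chain matters more, as neither a smaller halogen such as fluoro or chloro nor a shorter chain such as methyl or ethyl is among them. They also leave open how an amine or a carboxylic acid would behave at this carbon, and whether iodo would have the same effect with the stereocentre drawn as in compound 1.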